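A Ring Swap Tested Again on a Methylated Analogue

The compounds below may be only part of what the source reports. "The series", "measured", "known", "first", "only" and "open" are said of these compounds alone.

Measured so far:
compound 1, `N/C(=N\NC(=S)N1CCCCC1)c1ccccn1`, gives 68.1%
compound 2, `N/C(=N\NC(=S)N1CCCC1)c1ccccn1`, gives 77.2%
compound 3, `Cc1ccnc(/C(N)=N/NC(=S)N2CCCCC2)c1`, gives 39.7%

All three numbers come from a functional assay on A-431 cells (Homo sapiens) for cytotoxicity, read by MTT assay, with a stated time of 72 h, tested at 10 uM; on this read-out lower numbers stand for less inhibition of growth and higher numbers for more inhibition of growth at the one concentration tested. Two single changes connect these compounds. The first is pyrrolidin-1-yl in place of piperidin-1-yl on a thiocarbonyl carbon; it produced a number 9.1 percentage points higher from compound 1 to compound 2 (within the scatter), so compound 1 and compound 2 cannot be told apart on this read-out. The second is methyl in place of hydrogen on an aromatic carbon; it produced a number 28.4 percentage points lower from compound 1 to compound 3 (beyond the scatter), and compound 3 therefore sits at the low end of the three measured compounds, with both compound 1 and compound 2 beyond the scatter above it.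

Compound 4, `Cc1ccnc(/C(N)=N/NC(=S)N2CCCC2)c1`, has not yet been measured. It differs from compound 3 by pyrrolidin-1-yl in place of piperidin-1-yl on a thiocarbonyl carbon. This is the same change that leads from compound 1 to compound 2, made at the same place in the molecule, here on the core that carries the methyl group of compound 3. Because that earlier step was a number 9.1 percentage points higher from compound 1 to compound 2 (within the scatter), a similarly small movement is expected here, starting from the lower number of compound 3. The step from compound 3 to compound 4 is therefore estimated at a number 7.3 percentage points higher from compound 3 to compound 4 (within the scatter). Compound 4 is expected to give about 47%, most likely between 28% and 66%; this rests on one prior example of the change only, so the range is kept wide.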

Compound 4, percent growth inhibition at one concentration: 71.2%
Beside the measured number, compound 4's estimate is 24.2 percentage points below it, and the stated range ends below it.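

In this assay, the ring swap on the methylated core gave a number 31.5 percentage points higher from compound 3 to compound 4 (beyond the scatter), while adding the methyl group to the pyrrolidin-1-yl compound gave a number 6 percentage points lower from compound 2 to compound 4 (within the scatter), so the effect of each change here depends on what else the molecule carries. The swap of piperidin-1-yl for pyrrolidin-1-yl on the thiocarbonyl carbon therefore cannot be carried from one core to the other as a fixed step: the same change on two cores in this assay, a number 9.1 percentage points higher (within the scatter) from compound 1 to compound 2 and a number 31.5 percentage points higher (beyond the scatter) from compound 3 to compound 4, 22.4 percentage points apart, beyond the scatter of two such steps. Among these compounds, the methyl change tells the same story from the other side, though four compounds give only one such pair of cores and do not show why the two changes fail to add up: the same change on two cores in this assay, a number 28.4 percentage points lower (beyond the scatter) from compound 1 to compound 3 and a number 6 percentage points lower (within the scatter) from compound 2 to compound 4, 22.4 percentage points apart, beyond the scatter of two such steps.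

As far as these compounds go, it remains open whether the same dependence would appear with a morpholin-4-yl or dimethylamino group on the thiocarbonyl carbon, or with an ethyl group or a chlorine atom in place of the methyl. From the compounds shown here alone, since each compound is represented by a reading at a single concentration, it is also open whether the same pattern would hold across a full range of concentrations.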